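The source may hold more compounds than are shown below. What is called first, only, known or untested is meant among the compounds shown, and "the series" means these compounds.

Compound 1 `O=C(/C=C/c1cccs1)c1cc(O)c(O)c([N+](=O)[O-])c1` was examined in an assay on isolated protein for inhibition of Amine oxidase [flavin-containing] A (Homo sapiens), read by fluorescence (on this read-out higher numbers stand for weaker inhibition and lower numbers for stronger inhibition), where compound 1 gives 49900 nM. A second compound built on the same core, compound 2 `CC(=O)N1N=C(c2cc(O)c(O)c([N+](=O)[O-])c2)CC1c1nccs1`, was tested in this assay as well; compound 2 gives 84600 nM. Of the two numbers, that of compound 1 is the lower, but the gap to compound 2 lies within the usual scatter of repeated measurements, so the two compounds cannot be separated on potency. Going by the values given here, no pair of measured compounds differs in a single place, so there is no measured step to calibrate the next change.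

Compound 3 `O=C(/C=C/c1ccoc1)c1cc(O)c(O)c([N+](=O)[O-])c1` differs from compound 1 in one place: furan-3-yl in place of thiophen-2-yl on a double-bonded chain carbon bound to a double-bonded chain carbon. Among the compounds with values here, the group that leaves and the group that enters agree in what is counted, and nothing among the measured compounds points in either direction. Compound 3 is therefore expected to land close to compound 1, the estimated step from compound 1 to compound 3 being a 1.1-fold higher number from compound 1 to compound 3 (0.04 log units; within the scatter), not beyond the scatter. The estimate for compound 3 in this assay is 55000 nM, with an expected range from 20000 nM to 150000 nM.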

Compound 3, half-maximal inhibitory concentration: 52900 nM
Compound 3: middle estimate off by 1.0-fold (0.02 log units), on the high side; measured number inside the range.
By their numbers in this assay, from the lowest: compounds 1, 3 and 2 (each within the scatter of the next).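

In this assay, going by these compounds alone, exchanging thiophen-2-yl for furan-3-yl on a double-bonded chain carbon bound to a double-bonded chain carbon gives a 1.1-fold higher number from compound 1 to compound 3 (0.03 log units; within the scatter), the only measured single-place step in this set. It shows that at this place, one five-membered aromatic ring with 1 hetero atom can replace another, with sulfur giving way to oxygen and the point of attachment changing in the group's name, without a change that can be told from the scatter. No measurement shown here accounts for this result.

What remains open is whether a group of another kind at this place, such as a carboxylic acid, a dimethylamino group or a longer alkyl chain, would move the number beyond the scatter, since the one step shown covers only two closely matched rings. Within the data shown here, compound 2 differs from compound 1 and compound 3 in more than one place, so it provides no measured step for telling how its changes to the shared core act separately.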